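Swapping One Ring on a Side Chain

The compounds below may be only part of what the source reports. "The series", "measured", "known", "first", "only" and "open" are said of these compounds alone.

Of the compounds shown here, three with a shared core have been measured in a physicochemical assay for lipophilicity, at pH 7.4; a lower number here means a more polar compound, a higher number a more lipophilic compound. Compound 1 `CS(=O)(=O)Cc1cccc2c1CCC2c1ncc[nH]1` gives 0.7, compound 2 `COCc1cccc2c1CC[C@H]2c1ncc[nH]1` gives 1.8, and compound 3 `c1cc(Cn2cccn2)c2c(c1)[C@H](c1ncc[nH]1)CC2` gives 1.8. Compound 3 thus stands level with compound 2, while compound 1 lies lower by more than the usual scatter.

The next structure, compound 4 `Cc1noc(Cc2cccc3c2CC[C@H]3c2ncc[nH]2)n1`, keeps the core and has 3-methyl-1,2,4-oxadiazol-5-yl in place of 1H-pyrazol-1-yl on a saturated chain carbon bound to an aromatic carbon. Each group is a five-membered aromatic ring with no net charge.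

Among the compounds with values here, only one measured step bears directly on this place, with 1H-pyrazol-1-yl in place of methoxy, and it gave no change at the digits printed from compound 2 to compound 3 (within the scatter). Within the data shown here, no measured compound carries the incoming ring, so this evidence is thin, and the low value of compound 1 at 0.7 calls for a wide range. The expected change is small, a number 0.10 log units lower from compound 3 to compound 4 (within the scatter), which stays within the scatter. For compound 4 the estimated value in this assay is 1.7, with an expected range from 1.2 to 2.2.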

Compound 4, distribution coefficient: 2
For compound 4 the middle estimate is 0.30 log units below the measured one; measured number inside the range.
By their numbers in this assay, from the lowest: compound 1; then compounds 2, 3 and 4 (each within the scatter of the next).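

Exchanging 1H-pyrazol-1-yl for 3-methyl-1,2,4-oxadiazol-5-yl on a saturated chain carbon bound to an aromatic carbon gives a number 0.20 log units higher from compound 3 to compound 4 (within the scatter) in this assay, so at this position, one five-membered aromatic ring can replace another with more hetero atoms without a shift that stands clear of the scatter. Set against methoxy, the new ring gives a number 0.20 log units higher from compound 2 to compound 4 (within the scatter), so neither ring shows a difference from methoxy that can be told from the scatter. No supporting data are available to explain this flat result.

Going by these compounds, whether the same holds for an amine, a carboxylic acid or a longer chain at this position remains open. The compounds shown also do not separate the contribution of the methyl group from that of the oxadiazole ring that carries it.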